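This account rests on a few compounds, and the source may have more. Where it says the series, first, only, none or still open, it means among the compounds named here.

Compound 1 `Cc1cc(C)c(S(=O)(=O)N2CCC(N3CCC(C)CC3)CC2)c(C)c1` gives > 5000 nM (a limit)
Compound 2 `Cc1ccc(C2CCN(S(=O)(=O)c3c(C)cc(C)cc3C)CC2)cc1` gives > 5000 nM (a limit)
Compound 3 `Cc1cc(C)c(S(=O)(=O)N2CCC(N3CCCCCC3)CC2)c(C)c1` gives > 5000 nM (a limit)

In an ADME assay on HCT-116 cells (Homo sapiens) for cytotoxicity, read by CellTiter-Glo, with a stated time of 72 h (on this read-out higher numbers stand for weaker inhibition and lower numbers for stronger inhibition), compound 3 gives > 5000 nM as a limit and not a number. Compound 3 stands with the others at the limit of > 5000 nM in this assay, at which 3 of the 3 values shown sit, and no order among them can be read.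

Compound 4 `CCCC(=O)NC1CCN(S(=O)(=O)c2c(C)cc(C)cc2C)CC1` carries (propylcarbonyl)amino in place of azepan-1-yl on a saturated ring carbon, counted as (propylcarbonyl)amino in place of azepan-1-yl on a saturated ring carbon for this swap. The measured changes at this place are a step that the two limits leave unreadable from compound 1 to compound 2 and a step that the two limits leave unreadable from compound 1 to compound 3 and a step that the two limits leave unreadable from compound 2 to compound 3 and none of them offers a size to carry over. No direction can be told from these data, so the expected change is a step that the limit leaves unreadable from compound 3 to compound 4 in this assay and nothing beyond the scatter is anticipated. Compound 4 is estimated at 8000 nM within a range of 3000 nM to 20000 nM and will most likely be reported as a limit again.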

Compound 4, half-maximal inhibitory concentration: > 5000 nM
Compound 4: only a limit was reported (the forecaster's own chance of this, stated with the estimate: 90%); the middle value is on the limit's open side.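

No step among compound 1, compound 2, compound 3 and compound 4 can be read, since all four values are limits and not numbers: the limit of > 5000 nM in this assay, at which 4 of the 4 values shown sit.

Going by these compounds, whether any group on this saturated ring carbon would give a readable number stays open.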